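A few compounds are considered here, and "the series" means these few. Any claim that something is new, unique, unknown or untested is made for them only; others in the source may bear on it.

Series notes, measured in an ADME assay on a cell-free system (plasma, Homo sapiens) (on this read-out higher numbers stand for a larger free fraction and lower numbers for a smaller free fraction), so far:

- compound 1 `COc1c([C@H](C)Nc2ncnc3[nH]cnc23)cc(Cl)c(C)c1-c1cnn(C)c1` at 0.029 
- compound 2 `COc1c([C@H](C)Nc2ncnc(N)c2C#N)cc(Cl)c(C)c1-c1ccc(C(=O)N(C)C)cn1` at 0.22 
- compound 3 `COc1c([C@H](C)n2nc(C)c3c(N)ncnc32)cc(Cl)c(C)c1C1CNC(=O)C1` at 0.1 

Compound 2 stands highest of the three, and its value of 0.22 lies beyond the scatter from both other compounds. Compound 4 `COc1c([C@H](C)Nc2ncnc(N)c2C#N)cc(Cl)c(C)c1-c1cncc(S(C)(=O)=O)c1` has not yet been measured. It carries 5-(methylsulfonyl)pyridin-3-yl in place of 5-(dimethylcarbamoyl)pyridin-2-yl on an aromatic carbon and otherwise keeps the core of compound 2. Within the data shown here, no pair of measured compounds differs in one place only, so the series gives no direct precedent for this change. The expectation therefore starts from compound 2 at 0.22 and assumes little movement. The expected change is a 1.3-fold lower number from compound 2 to compound 4 (0.11 log units; within the scatter) in this assay as a small move towards a lower number, with no shift beyond the scatter anticipated. For compound 4 the estimate is 0.17 with an expected range from 0.09 to 0.3 in this assay for now.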

Compound 4, unbound fraction: 0.14
Estimate against measurement, compound 4: 1.2-fold (0.08 log units) above; the range from low to high includes it.
By their numbers in this assay, from the lowest: compound 1; then compounds 3, 4 and 2 (each within the scatter of the next, the first and the last beyond it).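

In this assay, among these compounds, the replacement of 5-(dimethylcarbamoyl)pyridin-2-yl by 5-(methylsulfonyl)pyridin-3-yl on this aromatic carbon, ortho to a methoxy group and ortho to a methyl group, gives a 1.6-fold lower number from compound 2 to compound 4 (0.20 log units; within the scatter) and is the first single-place reading for the series. On the core of compound 2, the free fraction therefore does not separate these two groups, although both the attachment to the ring and the substituent differ. No available data bear on the reason for this result.

Going by these compounds, because both features differ at once, the contribution of each remains open, as does the outcome of the same exchange on the cores of compound 1 and compound 3. Also open, on these data alone, is whether a carboxylic acid or an amine on the pyridine ring at this carbon would move the free fraction beyond the scatter.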